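A few compounds are considered here, and "the series" means these few. Any claim that something is new, unique, unknown or untested is made for them only; others in the source may bear on it.

Cytotoxicity in an ADME assay on RAW264.7 cells (Mus musculus) for cytotoxicity, read by MTT assay, with a stated time of 48 h, tested at 50 uM (a higher number here means more inhibition at the concentration tested (going by the name of the read-out), a lower number less inhibition), has been measured for three compounds of this set. Among the measured compounds shown here, compound 1 `N=C1S/C(=C\c2ccc(OCc3ccccc3)cc2)C(=O)N1c1ccccc1[N+](=O)[O-]` gives 24.4%, and compound 2 `Cc1ccc(C)c(N2C(=N)S/C(=C\c3ccc(OCc4ccccc4)cc3)C2=O)c1` gives 45.8%; between them stands the only one-place step so far, a number 21.4 percentage points higher from compound 1 to compound 2 (beyond the scatter). Compound 3 `NC(=O)c1c(NC(=O)c2ccc(Cl)cc2)sc2c1CCN(C(=O)c1ccccc1)C2`, built on a different core, gives 42.5% in this assay, the second highest of the three numbers; its value and that of compound 2 lie within the scatter of each other, while compound 1 sits lower by more than the scatter.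

Compound 4 `CN1CCc2c(sc(NC(=O)c3ccc(Cl)cc3)c2C(N)=O)C1` is the next candidate. It differs from compound 3 as follows: methyl in place of benzoyl on an amine nitrogen in a ring. For the measured compounds named here, no measured step bears on this change: the single step between compounds 1 and 2 concerns an amide-type nitrogen on another core and another kind of group, so it gives no guidance here. With nothing to support a shift in either direction, no step beyond the scatter is expected for this assay. The step of a number 4.5 percentage points lower from compound 3 to compound 4 (within the scatter) is therefore estimated as essentially flat. Compound 4 is expected to give about 38% in this assay, in the range 22% to 54%.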

Compound 4, a percentage reported as inhibition, at one concentration (the size of the read-out at that concentration, not a potency): 38.5%
For compound 4 the middle estimate is 0.5 percentage points below the measured one; the measured number falls inside the stated range.
By their numbers in this assay, from the lowest: compound 1; then compounds 4, 3 and 2 (each within the scatter of the next).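

At the amine nitrogen of the six-membered non-aromatic ring, this assay gives a number 4 percentage points lower from compound 3 to compound 4 (within the scatter) for methyl in place of benzoyl. Among the compounds shown here, this is the first step at this position, and it shows that the whole benzoyl group, aromatic ring included, can give way to methyl without the read-out at this concentration moving beyond the scatter. No measurement of any property accompanies this step, so nothing can be said about what lies behind it.

Open, from the compounds shown here alone, is whether a longer chain, a chain ending in an amine or a carboxylic acid, or simple hydrogen on this ring nitrogen would also stay within the scatter. One step on one core also leaves open whether the same change would read alike with another group in place of the chlorobenzoyl amide.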